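A few compounds are considered here, and "the series" means these few. Any claim that something is new, unique, unknown or untested is made for them only; others in the source may bear on it.

Measured in a functional assay on B16 cells (Mus musculus) for antiproliferative activity, with a stated time of 72 h; a lower number here means a stronger inhibitor, a higher number a weaker inhibitor:
- compound 1 `OC[C@H]1O[C@@H](n2cnc3c(NCc4cccc(F)c4)ncnc32)[C@H](O)[C@@H]1O`: "not determined" (no result reported)
- compound 2 `OC[C@H]1O[C@@H](n2cnc3c(NCc4ccc(Cl)cc4)ncnc32)[C@H](O)[C@@H]1O`: > 166000 nM
- compound 3 `Cc1ccc(CNc2ncnc3c2ncn3[C@@H]2O[C@H](CO)[C@@H](O)[C@H]2O)cc1`: "not determined" (no result reported)

Only compound 2 has a reported result, and compound 2 at > 166000 nM is a limit of the assay, not a number. Going by the values given here, no measured pair gives a step size for this series.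

Compound 4 `COc1cccc(CNc2ncnc3c2ncn3[C@@H]2O[C@H](CO)[C@@H](O)[C@H]2O)c1` carries 3-methoxyphenyl in place of 4-chlorophenyl on a saturated chain carbon bound to a nitrogen on an aromatic ring.

With the limit of > 166000 nM in this assay, at which 1 of the 3 values shown sits, as the only anchor, compound 2 gives no basis for expecting a step beyond the scatter in this assay, in either direction. The expected change is a number no higher from compound 2 to compound 4 (the limit leaves the size open). For compound 4 the estimate is 166000 nM, with an expected range of 50000 nM to 400000 nM.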

Compound 4, half-maximal inhibitory concentration: > 166000 nM
Compound 4: only a limit was reported (the forecaster's own chance of this, stated with the estimate: 70%); the middle value sits exactly at the limit.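

No step can be read between compound 2 and compound 4, since each is reported only as a limit in this assay: the limit of > 166000 nM in this assay, at which 2 of the 4 values shown sit.

The compounds shown leave open whether any change at this place on the shared core gives a measurable value in this assay.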